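The source may hold more compounds than are shown below. What is called first, only, known or untested is meant among the compounds shown, and "the series" means these compounds.

Measured so far:
compound 1 `Cc1cc(C)c(S(=O)(=O)N2CCC(N3CCC(c4ccccc4)CC3)CC2)c(C)c1`: > 5000 nM
compound 2 `CC1CCN(C2CCN(S(=O)(=O)c3cccc(N)c3)CC2)CC1`: > 5000 nM

Both results come from an ADME assay on HCT-116 cells (Homo sapiens) for cytotoxicity, read by CellTiter-Glo, with a stated time of 72 h; on this read-out lower numbers stand for stronger inhibition and higher numbers for weaker inhibition. Compound 1 gives > 5000 nM, which is a limit of the assay and not a number. Compound 2 gives > 5000 nM, which is likewise a limit. Compound 1 therefore stands at the limit of > 5000 nM in this assay, at which 2 of the 2 values shown sit. Within the data shown here, no step between measured compounds is available, and neither compound has a numerical potency.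

Compound 3 `Cc1cc(C)c(S(=O)(=O)N2CCC(N3CCC(Cc4ccccc4F)CC3)CC2)c(C)c1` keeps the core of compound 1 and changes one group, with 2-fluorobenzyl in place of phenyl on a saturated ring carbon.

Among the measured compounds shown here, the only guide to this change is the limit of compound 1, > 5000 nM, so no step beyond the scatter is expected in this assay, and no direction is favoured. The estimated change is a number no higher from compound 1 to compound 3 (the limit leaves the size open), and the result may well be reported only as a limit again. Compound 3 is estimated at 5000 nM, with an expected range from 2000 nM to 10000 nM.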

Compound 3, half-maximal inhibitory concentration: > 5000 nM
Compound 3: a limit, no number (the forecaster's own chance of this, stated with the estimate: 75%); the middle value lies on the limit itself.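

No step can be read from compound 1 to compound 3: in this assay compound 3 gives > 5000 nM, which is a limit of the assay and not a number. The compounds shown leave open how far each lies from that limit and whether any change to the shared core would give a numerical potency in this assay: the limit of > 5000 nM in this assay, at which 3 of the 3 values shown sit.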